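Sulfamoyl to methylsulfonyl on a shared bisaminopyrimidine scaffold

The compounds below may be only part of what the source reports. "The series", "measured", "known", "first", "only" and "open" are said of these compounds alone.

In a functional assay on PC-3 cells (Homo sapiens) for antiproliferative activity, read by MTT assay, with a stated time of 48 h (a lower number here means a stronger inhibitor, a higher number a weaker inhibitor), compound 1 `CS(=O)(=O)c1ccc(Nc2nccc(Nc3nc4ccc(F)cc4s3)n2)cc1` gives 1940 nM. Compound 2 `CS(=O)(=O)c1ccc(Nc2nccc(Nc3nc4ccc(Cl)cc4s3)n2)cc1` reaches only the limit of this assay, > 50000 nM. For the measured compounds named here, the step of an at least 25-fold higher number from compound 1 to compound 2 (1.41 log units; beyond the scatter) is the only measured step here (the limit of > 50000 nM in this assay, at which 1 of the 3 values shown sits). Compound 3 `COc1ccc2nc(Nc3ccnc(Nc4ccc(S(N)(=O)=O)cc4)n3)sc2c1` gives 3030 nM and sits alongside compound 1, the two values lying within the scatter of each other. Compound 4 `COc1ccc2nc(Nc3ccnc(Nc4ccc(S(C)(=O)=O)cc4)n3)sc2c1` differs from compound 3 by methyl in place of amino on a sulfonyl sulfur. Going by the values given here, no measured step touches the sulfonyl sulfur, so the halogen step offers no guide, and the expectation for compound 4 is a step within the scatter, a 1.0-fold lower number from compound 3 to compound 4 (0.00 log units; within the scatter). Compound 4 is therefore estimated at 3000 nM, within a range of 1000 nM to 9000 nM.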

Compound 4, half-maximal inhibitory concentration: 2700 nM
The estimate for compound 4 lay 1.1-fold (0.05 log units) above the measured number; the range from low to high includes it.
By their numbers in this assay, from the lowest: compounds 1, 4 and 3 (each within the scatter of the next). At a limit, above all of these: compound 2.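

In this assay, the sulfonyl sulfur now carries a measured step, a 1.1-fold lower number from compound 3 to compound 4 (0.05 log units; within the scatter), so the exchange of amino for methyl at this place stays within the scatter when the core bears methoxy. Compound 4 also links the methoxy series to the halogen compounds, with a 1.4-fold higher number from compound 1 to compound 4 (0.14 log units; within the scatter) and an at least 18-fold lower number from compound 2 to compound 4 (1.26 log units; beyond the scatter). Compound 2 stands at a limit and not at a number: the limit of > 50000 nM in this assay, at which 1 of the 4 values shown sits.

On these data alone, what an ethyl or a dimethylamino group on the sulfonyl sulfur would give stays open. So does whether amino and methyl on that sulfur would also read alike with fluoro or chloro in place of methoxy.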